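This account rests on a few compounds, and the source may have more. Where it says the series, first, only, none or still open, it means among the compounds named here.

Measured compounds:
compound 1 `CCCCCC(=O)c1c(O)c(Cl)c(O)c(Cl)c1O`: 102000 nM
compound 2 `CCCCCC(=O)c1c(O)c(Cl)c(C)c(Cl)c1O`: 13800 nM

In an ADME assay on the whole organism (strain S2) for cytotoxicity, with Drosophila as the target, read by WST assay (on this read-out lower numbers stand for higher toxicity in this test and higher numbers for lower toxicity in this test), compound 1 gives 102000 nM, the highest of the two numbers, so of the two it is the less toxic. For the measured compounds named here, its only neighbour is compound 2, reached by a 7.4-fold lower number from compound 1 to compound 2 (0.87 log units; beyond the scatter).

Compound 3 `CCCCCCCCC(=O)c1c(O)c(Cl)c(O)c(Cl)c1O` has not yet been tested. It differs from compound 1 by propyl in place of hydrogen on a saturated chain carbon, five bonds along the chain from a carbonyl carbon, that is, the chain attached to the carbonyl grows longer while the halogenated, triply hydroxylated core stays unchanged.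

Going by the values given here, none of the measured steps bears directly on this change. Among the compounds with values here, the one step known concerns the core, where a methyl replaces a hydroxy, and nothing comparable to a longer chain has been measured. The expectation therefore rests on the size of the known step alone, which shows that a single change can move the number well beyond the scatter, and on the change being small and far from the core. Compound 3 is estimated at 45000 nM, with a range from 12000 nM to 150000 nM, which would mean an expected 2.3-fold lower number from compound 1 to compound 3 (0.36 log units; beyond the scatter), with little confidence in its direction.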

Compound 3, half-maximal cytotoxic concentration: 82800 nM
Compound 3: middle estimate off by 1.8-fold (0.26 log units), on the low side; low and high end bracket the measured number.
By their numbers in this assay, from the lowest: compound 2; then compounds 3 and 1 (each within the scatter of the next).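

In this assay, placing propyl in place of hydrogen on a saturated chain carbon, five bonds along the chain from a carbonyl carbon, gives a 1.2-fold lower number from compound 1 to compound 3 (0.09 log units; within the scatter). For the compounds shown here, this is the first sign that the far end of the chain can grow by this much without a change that can be told from the usual spread of repeated measurements, at least when starting from compound 1. The two steps now known therefore differ in kind, since the change on the shared core, methyl in place of hydroxy, gave a 7.4-fold lower number from compound 1 to compound 2 (0.87 log units; beyond the scatter), while this change on the chain stays inside the scatter, and nothing shown here explains that difference.

On these data alone, it remains open whether this tolerance holds further out, for instance with a still longer chain, or whether it depends on the chain being a plain hydrocarbon, as an amine or a carboxylic acid at the chain end could give a very different number. Also open, as far as these compounds go, is whether the longer chain would leave the effect of methyl in place of hydroxy on the shared core intact if both changes were combined in a single compound.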